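Aryl replacement on the benzyl arm of the anilide series

The compounds below may be only part of what the source reports. "The series", "measured", "known", "first", "only" and "open" are said of these compounds alone.

Values in an assay on isolated protein with Bile acid receptor (Homo sapiens) as the target; a lower number here means that less compound is needed, a higher number that more compound is needed for the effect:
compound 1 `COC(=O)/C=C/c1cccc(N(Cc2ccc(/C=C/c3ccccn3)cc2)C(=O)C2CCCCC2)c1`: 309 nM
compound 2 `COC(=O)/C=C/c1cccc(N(Cc2ccc(-c3ccc(C(C)(C)C)cc3)cc2)C(=O)C2CCCCC2)c1`: 132 nM
compound 3 `COC(=O)/C=C/c1ccc(CN(C(=O)C2CCCCC2)c2cccc(/C=C/C(=O)OC)c2)cc1`: > 1000 nM, a limit of the assay

Compound 3 stands only at a limit in this assay, so its true number is not known (the limit of > 1000 nM in this assay, at which 1 of the 3 values shown sits). Compound 4 `COC(=O)/C=C/c1cccc(N(Cc2ccc(-c3ccc(SC)cc3)cc2)C(=O)C2CCCCC2)c1` differs from it by 4-(methylsulfanyl)phenyl in place of 2-(methoxycarbonyl)ethenyl on an aromatic carbon. The closest measured step is an at least 7.5-fold higher number from compound 2 to compound 3 (0.87 log units; beyond the scatter), which runs the opposite way and shows that an aryl group here gives a clearly lower number than the ester-bearing chain; an at least 3.2-fold higher number from compound 1 to compound 3 (0.51 log units; beyond the scatter) points the same way, and a 2.3-fold lower number from compound 1 to compound 2 (0.37 log units; beyond the scatter) shows the aryl variant as the better of the two. A step of at least that size downward, an at least 5.0-fold lower number from compound 3 to compound 4 (0.69 log units; beyond the scatter), is therefore expected. Compound 4 is estimated at 200 nM, within 80 nM to 600 nM.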

Compound 4, half-maximal effective concentration: 69 nM
Compound 4: the middle estimate sits 2.9-fold (0.46 log units) above what was measured; measured number outside the range, below it.
By their numbers in this assay, from the lowest: compounds 4 and 2 (each within the scatter of the next); then compound 1. At a limit, above all of these: compound 3.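

In this assay, within the data shown here, 4-(methylsulfanyl)phenyl on this aromatic carbon gives the largest step so far, an at least 14-fold lower number from compound 3 to compound 4 (1.16 log units; beyond the scatter). Compound 3 stands only at a limit, so that step is a bound: the limit of > 1000 nM in this assay, at which 1 of the 4 values shown sits. Methylsulfanyl in place of tert-butyl stays within the scatter, a 1.9-fold lower number from compound 2 to compound 4 (0.28 log units; within the scatter), so these two groups cannot be ordered, while a 4.5-fold lower number from compound 1 to compound 4 (0.65 log units; beyond the scatter) sets the 2-(pyridin-2-yl)ethenyl compound apart from this aryl group as well.

On these data alone, whether an unsubstituted phenyl, or a phenyl bearing a carboxylic acid or an amine, would hold the number stays open. As far as these compounds go, the contribution of the methoxycarbonyl group on the shared core also stays open.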